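The source may report more compounds than this note shows. Statements on the series, on what has been measured and on what is new or still open speak of the compounds shown alone.

Measured compounds:
Compound 1 `O=c1nc(N2CCN(CC3CCCCC3)CC2)sc2c([N+](=O)[O-])cc(C(F)(F)F)cc12` gives 9.07 ug/mL in a physicochemical assay for solubility, read by HPLC; on this read-out higher numbers stand for higher solubility and lower numbers for lower solubility.
Compound 2 `CCCC(=O)N1CCN(c2nc(=O)c3cc(C(F)(F)F)cc([N+](=O)[O-])c3s2)CC1` gives 2.46 ug/mL in this assay.
Compound 3 `O=C(c1ccccc1Cl)N1CCN(c2nc(=O)c3cc(C(F)(F)F)cc([N+](=O)[O-])c3s2)CC1` gives 8.18 ug/mL in this assay.

Compound 3 stands second highest of the three numbers. Its nearest neighbour is compound 1, reached by a 1.1-fold lower number from compound 1 to compound 3 (0.04 log units; within the scatter), a gap within the scatter. Its furthest neighbour is compound 2, and a 3.3-fold higher number from compound 2 to compound 3 (0.52 log units; beyond the scatter) lies beyond the scatter.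

Compound 4 `CC(C)(C)C1CCC(C(=O)N2CCN(c3nc(=O)c4cc(C(F)(F)F)cc([N+](=O)[O-])c4s3)CC2)CC1` differs from compound 3 at the carbonyl carbon: 4-(tert-butyl)cyclohexyl in place of 2-chlorophenyl on a carbonyl carbon

Within the data shown here, only one measured step touches that position, a 3.3-fold higher number from compound 2 to compound 3 (0.52 log units; beyond the scatter), in which propyl gave way to 2-chlorophenyl. The other steps, a 3.7-fold lower number from compound 1 to compound 2 (0.57 log units; beyond the scatter) and a 1.1-fold lower number from compound 1 to compound 3 (0.04 log units; within the scatter), change the substituent on the amine nitrogen in the ring and do not speak to this change. Among the measured compounds shown here, no measured pair places a 4-(tert-butyl)cyclohexyl group on the carbonyl carbon, so the expectation rests on compound 2 alone, which carries the only saturated carbon group at that place and gives 2.46 ug/mL. A modest fall in this assay is therefore expected, of a size near that seen from compound 2 to compound 3 but in the opposite direction.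

Compound 4 is estimated at 3 ug/mL, with a range from 1 ug/mL to 9 ug/mL. This estimate corresponds to a 2.7-fold lower number from compound 3 to compound 4 (0.44 log units; beyond the scatter).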

Compound 4, solubility: < 0.1 ug/mL
Compound 4: only a limit was reported; the forecaster's own chance of this, stated with the estimate: 5%; at least 30-fold (1.47 log units) between middle value and limit.
By their numbers in this assay, from the lowest: compound 2; then compounds 3 and 1 (each within the scatter of the next). At a limit, below all of these: compound 4.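

In this assay, among these compounds, the carbonyl carbon proves to hold a far larger effect than the earlier compounds showed: 4-(tert-butyl)cyclohexyl in place of 2-chlorophenyl gives an at least 81-fold lower number from compound 3 to compound 4 (1.91 log units; beyond the scatter) and in place of propyl gives an at least 24-fold lower number from compound 2 to compound 4 (1.39 log units; beyond the scatter) while the earlier change at that place was the modest 3.3-fold higher number from compound 2 to compound 3 (0.52 log units; beyond the scatter) alone. Counting the whole substituent on the amine nitrogen in the ring, the result is an at least 90-fold lower number from compound 1 to compound 4 (1.95 log units; beyond the scatter) and the carbonyl alone does not set it, for compound 2 and compound 3 carry a carbonyl there too and still give numbers. Compound 4 gives no number, only a limit, so each of these steps is a bound on its size and the true size stays unknown: the limit of < 0.1 ug/mL in this assay, at which 1 of the 4 values shown sits.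

The compounds shown leave open whether the fall follows the tert-butyl group or the cyclohexyl ring, a question that a plain cyclohexyl on the carbonyl carbon would help to separate. They also leave open how an amine or a carboxylic acid on that cyclohexyl ring, or a longer chain in place of propyl, would read in this assay on this scale.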